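The compounds below may be only part of what the source reports. "The series", "measured", "known", "first", "only" and "open" are said of these compounds alone.

Compound 1 `CC(=O)c1ccc(NC(=O)/C=C/C(=O)N2C/C(=C\c3ccc([N+](=O)[O-])cc3)C(=O)/C(=C/c3ccc([N+](=O)[O-])cc3)C2)cc1`: 1400 nM
Compound 2 `O=C(/C=C/C(=O)N1C/C(=C\c2ccc([N+](=O)[O-])cc2)C(=O)/C(=C/c2ccc([N+](=O)[O-])cc2)C1)Nc1ccc(Cl)cc1`: 3600 nM

Of the compounds shown here, two have been tested in a functional assay on L1210 cells (Mus musculus) for cytotoxicity; a lower number here means a stronger inhibitor, a higher number a weaker inhibitor. Compound 1 gives 1400 nM, and compound 2 gives 3600 nM, which is the higher of the two numbers. Within the data shown here, the only step available, a 2.6-fold higher number from compound 1 to compound 2 (0.41 log units; beyond the scatter), exchanges the acetyl for chloro on an aromatic carbon and leaves compound 2 as the weaker of the pair.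

Compound 3 `Cc1ccc(NC(=O)/C=C/C(=O)N2C/C(=C\c3ccc([N+](=O)[O-])cc3)C(=O)/C(=C/c3ccc([N+](=O)[O-])cc3)C2)cc1` differs from compound 2 in one place: methyl in place of chloro on an aromatic carbon. Among the measured compounds shown here, no measured step bears directly on a methyl entering for a chloro; the single step from compound 1 to compound 2 concerns a different pair of groups and was modest in size. With nothing in hand to point to a shift in either direction, the number for compound 3 is expected to stay close to that of compound 2, so the estimated step of a 1.0-fold lower number from compound 2 to compound 3 (0.01 log units; within the scatter) is taken as none beyond the scatter. Compound 3 is therefore estimated at 3500 nM, within a range from 1500 nM to 8000 nM.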

Compound 3, half-maximal inhibitory concentration: 4400 nM
Beside the measured number, compound 3's estimate is 1.3-fold (0.10 log units) below it; measured number inside the range.
By their numbers in this assay, from the lowest: compound 1; then compounds 2 and 3 (each within the scatter of the next).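

In this assay, methyl in place of chloro on the aromatic carbon para to a large group gives a 1.2-fold higher number from compound 2 to compound 3 (0.09 log units; within the scatter), so at this position these two groups, each of one heavy atom and with no hydrogen-bond donors or acceptors, cannot be told apart. Acetyl now stands apart from both rather than from chloro alone: methyl in place of acetyl gives a 3.1-fold higher number from compound 1 to compound 3 (0.50 log units; beyond the scatter), which leaves compound 1 as the strongest inhibitor of the three, though the step is modest. No measurement at hand explains why the acetyl compound differs from the other two.

The compounds shown leave open whether the lower number belongs to acetyl alone or also extends to other carbonyl-bearing groups at this position, such as a methyl ester, a primary carboxamide or a carboxylic acid. They also do not show how an amine, a methoxy group or a longer alkyl chain would behave in the same place, or whether a bare hydrogen there would fall with chloro and methyl or with acetyl.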